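The source may hold more compounds than are shown below. What is called first, only, known or untested is meant among the compounds shown, and "the series" means these compounds.

Working notes on the series. Compound 1 `Cc1ccccc1-n1nncc1CN1C(=O)C2(C(C#N)=C(N)Oc3c2c2nc4ccccc4nc2c2ccccc32)c2ccccc21` in an ADME assay on HUVEC cells (Homo sapiens) for antiproliferative activity, read by MTT assay, with a stated time of 48 h (on this read-out lower numbers stand for stronger inhibition and higher numbers for weaker inhibition), gives only a limit of the assay, > 50000 nM. Compound 2 `Cc1cccc(-n2nncc2CN2C(=O)C3(C(C#N)=C(N)Oc4c(N)cc5nc6ccccc6nc5c43)c3ccccc32)c1` in this assay likewise gives a limit, > 50000 nM. Compound 3 `CC(=O)Nc1ccc(-n2nncc2CN2C(=O)C3(C(C#N)=C(N)Oc4c(N)cc5nc6ccccc6nc5c43)c3ccccc32)cc1` in this assay also returns a limit, > 50000 nM. For the measured compounds named here, compound 3 therefore stands where every value so far stands: the limit of > 50000 nM in this assay, at which 3 of the 3 values shown sit. Going by the values given here, the only measured step between neighbours, a step that the two limits leave unreadable from compound 2 to compound 3, is unreadable for this reason. Compound 4 `CCc1cccc(C)c1-n1nncc1CN1C(=O)C2(C(C#N)=C(N)Oc3c(N)cc4nc5ccccc5nc4c32)c2ccccc21` differs from compound 3 by 2-ethyl-6-methylphenyl in place of 4-acetamidophenyl on an aromatic nitrogen. Among the compounds with values here, no measured step bears readably on this change, and the three limits give no direction. Compound 4 is therefore expected to remain at the limit, with a step that the limit leaves unreadable from compound 3 to compound 4 expected to be nothing beyond the scatter. The estimate for compound 4 in this assay is 80000 nM, within 30000 nM to 300000 nM.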

Compound 4, half-maximal inhibitory concentration: > 50000 nM
Compound 4: no number, only a limit; the forecaster's own chance of this, stated with the estimate: 85%; the middle value does not contradict the limit.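

Compound 4 in this assay gives only a limit, > 50000 nM. For the compounds shown here, no step from compound 2 or compound 3 to compound 4 can be read. The compounds shown leave open whether any group on the aromatic nitrogen gives a measurable value.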